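A ring swap in a growth-inhibition series

The source may hold more compounds than are shown below. What is called first, only, known or untested is meant among the compounds shown, and "the series" means these compounds.

- Compound 1 `O=C(/C(=C\c1ccc2ccccc2n1)SCc1ccc(F)cc1)c1ccc(Br)cc1` (25000 nM)
- Compound 2 `Cc1ccc(C)c(/C=C(/SCc2ccc(F)cc2)C(=O)c2ccc(Br)cc2)c1` (1000 nM)

Within the data shown here, both compounds were measured in a functional assay on DU-145 cells (Homo sapiens) for inhibition, read by trypan blue exclusion, with a stated time of 96 h (a higher number here means a weaker inhibitor of growth, a lower number a stronger inhibitor of growth), and compound 2 holds the lower of the two numbers (1000 nM), with compound 1 as its only neighbour. Among the measured compounds shown here, the one measured step is a 25-fold lower number from compound 1 to compound 2 (1.40 log units; beyond the scatter) and it lies beyond the scatter. It falls on a double-bonded chain carbon bound to a double-bonded chain carbon, the same place that changes next.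

Compound 3 `Cc1cc(F)ccc1/C=C(/SCc1ccc(F)cc1)C(=O)c1ccc(Br)cc1` keeps the shared core and differs only there (4-fluoro-2-methylphenyl in place of 2,5-dimethylphenyl on a double-bonded chain carbon bound to a double-bonded chain carbon), with 4-fluoro-2-methylphenyl in place of 2,5-dimethylphenyl. That measured step replaced quinolin-2-yl, so it shows that this place can matter in this assay but does not describe a swap of this kind. For the measured compounds named here, no measured pair tests the new group directly. A change within the scatter is therefore expected, with no firm direction. The expected step is no change at the digits printed from compound 2 to compound 3 (within the scatter) in this estimate. Compound 3 is expected at 1000 nM (estimated range from 300 nM to 3500 nM).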

Compound 3, concentration for 50% growth inhibition: 10000 nM
For compound 3 the middle estimate is 10-fold (1.00 log units) below the measured one; the whole stated range lies below it.
By their numbers in this assay, from the lowest: compound 2; then compound 3; then compound 1.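

In this assay, the place on a double-bonded chain carbon bound to a double-bonded chain carbon responds not only to the loss of quinolin-2-yl but also to a smaller swap between two substituted phenyl groups: 4-fluoro-2-methylphenyl in place of 2,5-dimethylphenyl gives a 10-fold higher number from compound 2 to compound 3 (1.00 log units; beyond the scatter) even though the two groups match in their counted heavy atoms, ring, donors, acceptors and charge. Putting 4-fluoro-2-methylphenyl in place of quinolin-2-yl gives a 2.5-fold lower number from compound 1 to compound 3 (0.40 log units; beyond the scatter) so a substituted phenyl group at this place does not by itself bring the number down to that of compound 2, and the groups on the ring also count. Nothing measured here explains why these two rings differ, and no outside measurement bears on this step.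

The swap from compound 2 to compound 3 removes one methyl and adds a fluorine in a single move, so the compounds shown cannot separate what each of those changes contributes. Also open, on these data alone, is how this place would respond to a ring carrying a methoxy group, an amine or a carboxylic acid, or to a plain unsubstituted phenyl ring.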